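The source may report more compounds than this note shows. Statements on the series, on what has been measured and on what is new or still open speak of the compounds shown alone.

In an ADME assay on microsomes from liver (Homo sapiens) for metabolic stability, read by LC-MS, using NADPH, tested at 5 uM (a lower number here means that the compound disappears faster, a higher number that the compound lasts longer), compound 3 `NS(=O)(=O)c1cc(-c2nnc(/C=C/c3ccccc3)o2)c(Cl)cc1SCc1ccccc1` gives 0.228 h, the second highest of the three numbers measured. Compound 2 `NS(=O)(=O)c1cc(-c2nnc(Cn3cc(-c4ccccc4)nn3)o2)c(Cl)cc1SCc1ccccc1` gives 0.21 h, and compound 1 `CN1CCN(Cc2nnc(-c3cc(S(N)(=O)=O)c(SCc4ccccc4)cc3Cl)o2)CC1` gives 0.308 h. The measured steps all lie within the scatter: a 1.4-fold lower number from compound 1 to compound 3 (0.13 log units; within the scatter) and a 1.1-fold higher number from compound 2 to compound 3 (0.04 log units; within the scatter), and each of them exchanges the substituent on the far side of the shared core rather than touching the phenyl at the end of the ethenyl chain. Compound 4 `NS(=O)(=O)c1cc(-c2nnc(/C=C/c3ccc(Cl)cc3)o2)c(Cl)cc1SCc1ccccc1` differs from compound 3 by chloro in place of hydrogen on an aromatic carbon. Among the compounds with values here, no measured step covers such a change, so the expectation rests on the general flatness of the set. The step of a 1.1-fold higher number from compound 3 to compound 4 (0.04 log units; within the scatter) is therefore expected to stay within the scatter. For compound 4 the half-life is estimated at 0.25 h, with a range from 0.12 h to 0.5 h.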

Compound 4, half-life: 0.207 h
Compound 4: the middle estimate sits 1.2-fold (0.08 log units) above what was measured; the measured number falls inside the stated range.
By their numbers in this assay, from the lowest: compounds 4, 2, 3 and 1 (each within the scatter of the next).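

Within the data shown here, the 2-(4-chlorophenyl)ethenyl compound gives the first reading for a change on the phenyl at the end of the chain: in this assay there is a 1.1-fold lower number from compound 3 to compound 4 (0.04 log units; within the scatter), so chloro in place of hydrogen, para to a large group, cannot be told apart from hydrogen here. Compared with the other substituents, there is a 1.0-fold lower number from compound 2 to compound 4 (0.01 log units; within the scatter) and a 1.5-fold lower number from compound 1 to compound 4 (0.17 log units; within the scatter), so this group also stays inside the flat set. Nothing available explains this reading.

From the compounds shown here alone, whether an amine or a carboxylic acid in place of the chloro would give a half-life beyond the scatter stays open. So does the effect of a longer chain between the shared core and the phenyl.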